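The source may report more compounds than this note shows. Statements on the series, on what has been measured and on what is new or still open speak of the compounds shown alone.

In an ADME assay on microsomes from liver (Homo sapiens) for metabolic stability, with a stated time of 10 min (a lower number here means that less of the compound is left, a higher number that more of the compound is left), compound 1 (`O=C(O)C12CCC(C(=O)N3CC[C@](c4ccc(C(F)(C(F)(F)F)C(F)(F)F)cc4)(S(=O)(=O)c4ccc(F)cc4)C3)(CC1)OC2`) stands at 90% on the read-out, compound 2 (`O=C([C@H]1CC[C@H](c2nnn[nH]2)CC1)N1CC[C@](c2ccc(C(F)(C(F)(F)F)C(F)(F)F)cc2)(S(=O)(=O)c2ccc(F)cc2)C1`) at 100% and compound 3 (`NC(=O)[C@H]1CC[C@H](C(=O)N2CC[C@](c3ccc(C(F)(C(F)(F)F)C(F)(F)F)cc3)(S(=O)(=O)c3ccc(F)cc3)C2)CC1`) at 100% in the same series. Compound 3 is therefore level with compound 2, and no gap among the three lies beyond the scatter. Compound 4 (`O=C([C@H]1CC[C@H](CO)CC1)N1CC[C@](c2ccc(C(F)(C(F)(F)F)C(F)(F)F)cc2)(S(=O)(=O)c2ccc(F)cc2)C1`) has hydroxymethyl in place of carbamoyl on a saturated ring carbon three ring bonds from the ring atom that bears a large group. Going by the values given here, the steps that bear on this change all alter the same end of the molecule. Carbamoyl in place of 1H-tetrazol-5-yl gave no change at the digits printed from compound 2 to compound 3 (within the scatter) and the two replacements of the group in compound 1 gave a number 10 percentage points higher from compound 1 to compound 2 (within the scatter) and a number 10 percentage points higher from compound 1 to compound 3 (within the scatter) in turn. Among the compounds with values here, no measured compound carries hydroxymethyl, so the series offers no direct precedent for it. Resting on no change at the digits printed from compound 2 to compound 3 (within the scatter) as the closest guide, a number 7 percentage points lower from compound 3 to compound 4 (within the scatter) is the expected step in this assay and none beyond the scatter is foreseen. For compound 4 the estimate is 93% with an expected range of 80% to 100% on this read-out.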

Compound 4, percent of the compound remaining: 75%
The estimate for compound 4 lay 18 percentage points above the measured number, outside the stated range (below it).
By their numbers in this assay, from the lowest: compound 4; then compounds 1, 2 and 3 (each within the scatter of the next).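

In this assay, going by these compounds alone, the group on this saturated ring carbon now moves the read-out beyond the scatter for the first time: hydroxymethyl in place of carbamoyl gives a number 25 percentage points lower from compound 3 to compound 4 (beyond the scatter), and hydroxymethyl in place of 1H-tetrazol-5-yl gives a number 25 percentage points lower from compound 2 to compound 4 (beyond the scatter). The larger replacement on the carbonyl carbon gives a number 15 percentage points lower from compound 1 to compound 4 (beyond the scatter), so compound 4 is the lowest of the four, while the other three remain within the scatter of one another. No measurement at hand accounts for these steps.

Going by these compounds, it remains open whether the fall belongs to hydroxymethyl alone or extends to other groups on a saturated ring carbon, such as an aminomethyl group, a methoxymethyl group or a longer chain like 2-hydroxyethyl. On these data alone, it also remains open whether the step holds at longer incubation times.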